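Allyloxycarbonyl in place of pentanoyl on the shared core

This account rests on a few compounds, and the source may have more. Where it says the series, first, only, none or still open, it means among the compounds named here.

Compound 2 `CCCCC(=O)Oc1ccc(/C=C/C(=O)c2c(OC)cc3c(c2O)CCC(C)(C)O3)cc1` was tested in an assay on HEK293T cells for inhibition of nuclear factor NF-kappa-B complex (Homo sapiens), read by a luciferase reporter (a lower number here means a stronger inhibitor, a higher number a weaker inhibitor), and gives only a limit of the assay, > 30000 nM. Compound 1 `COc1cc2c(c(O)c1C(=O)/C=C/c1ccc(OC(=O)c3ccc(Cl)nc3)cc1)CCC(C)(C)O2` likewise gives a limit in this assay, > 30000 nM. Compound 3 `COc1cc2c(c(O)c1C(=O)/C=C/c1ccc(OC(C)=O)cc1)CCC(C)(C)O2` also gives a limit, > 30000 nM. All three sit together at the limit of > 30000 nM in this assay, at which 3 of the 3 values shown sit, so the steps a step that the two limits leave unreadable from compound 1 to compound 2, a step that the two limits leave unreadable from compound 1 to compound 3 and a step that the two limits leave unreadable from compound 2 to compound 3 have no readable size. Compound 4 `C=CCOC(=O)Oc1ccc(/C=C/C(=O)c2c(OC)cc3c(c2O)CCC(C)(C)O3)cc1` differs from compound 2 by allyloxy in place of butyl on a carbonyl carbon. Since every measured step at this carbonyl carbon is unreadable, no direction for compound 4 can be drawn from them. Compound 4 is therefore expected to remain near the limit, with the step that the limit leaves unreadable from compound 2 to compound 4 estimated as small. The estimate for compound 4 is 45000 nM, ranging from 10000 nM to 200000 nM.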

Compound 4, half-maximal inhibitory concentration: > 30000 nM
Compound 4: only a limit was reported; the forecaster's own chance of this, stated with the estimate: 85%; the middle value does not contradict the limit.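

Compound 4 gives only a limit, as do compound 1, compound 2 and compound 3, so none of its steps to these three can be read: the limit of > 30000 nM in this assay, at which 4 of the 4 values shown sit. The compounds shown leave open whether any group on this carbonyl carbon gives a measurable value in this assay.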